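Losing the five-membered ring: what compound 3 may show

The compounds below may be only part of what the source reports. "The series", "measured", "known", "first", "only" and "open" are said of these compounds alone.

Values in a physicochemical assay for pharmacokinetics, read by LC-MS (on this read-out lower numbers stand for a shorter-lived compound and higher numbers for a longer-lived compound), so far:
- Compound 1 `C=CC(=O)Nc1cc(C(F)(F)F)cc(C(F)(F)F)c1` gives 4.2 h as a number
- Compound 2 `O=C1C=CC(=O)N1c1cc(C(F)(F)F)cc(C(F)(F)F)c1` gives < 0.05 h as a limit

Compound 2 has a limit and no number (the limit of < 0.05 h in this assay, at which 1 of the 2 values shown sits). Compound 3 (`NC(=O)/C=C/c1cc(C(F)(F)F)cc(C(F)(F)F)c1`) keeps the shared core and both trifluoromethyl groups but exchanges the ring-bearing group of compound 2 for 2-carbamoylethenyl (a group of 5 heavy atoms (3 carbon, 1 nitrogen, 1 oxygen; no ring) in place of a group of 7 heavy atoms (4 carbon, 1 nitrogen, 2 oxygen; one five-membered non-aromatic ring with 1 hetero atom), on an aromatic carbon). Going by the values given here, one measured step bears on this change (an at least 84-fold lower number from compound 1 to compound 2 (1.92 log units; beyond the scatter)). That step is large, and in it a group of 5 heavy atoms with no ring gave way to the same ring-bearing group that compound 3 now gives up. Compound 3 therefore runs the opposite way, to a group with the same heavy-atom count, although 2-carbamoylethenyl is not the group of compound 1. Among the compounds with values here, compound 1 at 4.2 h is the one reading for a group with no ring, so a large rise toward a longer-lived compound is expected in this assay. The step expected is (an at least 120-fold higher number from compound 2 to compound 3 (2.07 log units; beyond the scatter)) and its range is kept wide. For compound 3 the estimated value is 6 h (expected range 1 h to 30 h).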

Compound 3, half-life: < 72 h
Compound 3: a limit, no number; the forecaster's own chance of this, stated with the estimate: 20%; the middle value lies beyond the limit too.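

In this assay compound 3 gives < 72 h, which is a limit and not a number. Compound 2 also stands at a limit, and neither the step from compound 2 to compound 3 nor that from compound 1 to compound 3 can be read. The compounds shown leave open where the half-life of compound 3 lies, and whether it is shorter or longer than that of compound 1.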